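Dichloroacetamide biaryls: distal phenyl exchanged for trifluoromethyl

This account rests on a few compounds, and the source may have more. Where it says the series, first, only, none or still open, it means among the compounds named here.

Compound 1 `O=C(Nc1cccc(-c2ccc(-c3ccccc3)cc2)c1)C(Cl)Cl` gives 10900 nM in a functional assay on NCI-H460 cells (Homo sapiens) for cytotoxicity, read by MTT assay, with a stated time of 68 h; a higher number here means a weaker inhibitor, a lower number a stronger inhibitor. Among the three numbers it stands second highest. Compound 3 `CCOc1ccc(-c2cc(NC(=O)C(Cl)Cl)cc(-c3ccc(OCC)cc3)c2)cc1` gives 6080 nM, which lies within the scatter of compound 1, whereas compound 2 `Cc1ccccc1-c1cccc(NC(=O)C(Cl)Cl)c1` gives 31600 nM, a gap beyond the scatter. Compound 4 `O=C(Nc1cccc(-c2ccc(C(F)(F)F)cc2)c1)C(Cl)Cl` is not yet measured in this assay. It differs from compound 1 by trifluoromethyl in place of phenyl on an aromatic carbon. Within the data shown here, no step between measured compounds isolates this exchange; what the numbers show is only that compound 2 returns a higher number than compound 1. A step toward a weaker inhibitor is therefore expected, modest in size. The step of a 1.8-fold higher number from compound 1 to compound 4 (0.26 log units; within the scatter) is expected to exceed the scatter by little. Compound 4 is estimated at 20000 nM, with a range from 8000 nM to 50000 nM.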

Compound 4, half-maximal inhibitory concentration: 33600 nM
Compound 4: middle estimate off by 1.7-fold (0.23 log units), on the low side; low and high end bracket the measured number.
By their numbers in this assay, from the lowest: compounds 3 and 1 (each within the scatter of the next); then compounds 2 and 4 (each within the scatter of the next).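

In this assay, among these compounds, trifluoromethyl in place of phenyl on an aromatic carbon, para to a large group, gives a 3.1-fold higher number from compound 1 to compound 4 (0.49 log units; beyond the scatter) and a weaker inhibitor, the first exchange read at a single place. This position therefore responds to the change, and a six-membered aromatic ring of carbon only is not replaced here by trifluoromethyl without loss. No measurement at hand explains the step. From the compounds shown here alone, whether a pyridine ring at this position would hold the number of compound 1 stays open. An amine, a carboxylic acid or a longer alkyl chain there also remains untested in the compounds shown.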